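The source may hold more compounds than are shown below. What is called first, only, known or untested is meant among the compounds shown, and "the series" means these compounds.

Measured in a functional assay on SF-268 cells (Homo sapiens) for inhibition, read by sulforhodamine B assay, with a stated time of 48 h; a higher number here means a weaker inhibitor of growth, a lower number a stronger inhibitor of growth
compound 1 `N#CCC1=NN=C(c2ccc([N+](=O)[O-])cc2)CO1` gives 1800 nM
compound 2 `N#CCC1=NN=C(c2ccc(Br)cc2)C(Br)O1` gives 32000 nM
compound 3 `N#CCC1=NN=C(c2ccc([N+](=O)[O-])cc2)C(CC(=O)c2ccc(Br)cc2)O1` gives 16500 nM

Compound 2 and compound 3 lie within the usual scatter of each other at the high end of these numbers, and compound 1 stands clearly lower.

Compound 4 `N#CCC1=NN=C(c2ccc([N+](=O)[O-])cc2)C(Br)O1` has not yet been measured. It differs from compound 2 in one place, and nitro in place of bromo on an aromatic carbon is that change: nitro in place of bromo on an aromatic carbon. Within the data shown here, compound 1 and compound 3 also carry nitro, yet each differs from compound 4 elsewhere, so no measured pair shows this swap alone. Compound 1 at 1800 nM shows that a nitro compound can reach a low number, while compound 3 at 16500 nM shows that one can also stay high. A moderate step toward a lower number is therefore expected in this assay and a 4.0-fold lower number from compound 2 to compound 4 (0.60 log units; beyond the scatter) is its estimated size, though this rests on thin evidence. For compound 4 the estimated value is 8000 nM with 2000 nM to 32000 nM as the expected range.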

Compound 4, concentration for 50% growth inhibition: 6700 nM
Compound 4: the middle estimate sits 1.2-fold (0.08 log units) above what was measured, within the range that was stated.
By their numbers in this assay, from the lowest: compound 1; then compound 4; then compounds 3 and 2 (each within the scatter of the next).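

In this assay the swap of nitro in place of bromo on an aromatic carbon, para to a large group, can now be read alone, with the rest of the molecule unchanged: it gives a 4.8-fold lower number from compound 2 to compound 4 (0.68 log units; beyond the scatter). The second step isolates another place, as bromo in place of hydrogen on a saturated ring carbon, with nitro kept, gives a 3.7-fold higher number from compound 1 to compound 4 (0.57 log units; beyond the scatter); each of the two places therefore moves the number by more than the usual scatter. No measured data here explain why either change has this effect.

From the compounds shown here alone, how an amine or a carboxylic acid on that aromatic carbon would compare with nitro and bromo remains open. So does whether a methyl group on the saturated ring carbon would behave more like hydrogen or like bromo.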